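This account rests on a few compounds, and the source may have more. Where it says the series, first, only, none or still open, it means among the compounds named here.

Compound 1 `c1coc(-c2ccccc2OCC2=NCCN2)c1` reaches 106% in a functional assay with Alpha-1A adrenergic receptor (Homo sapiens) as the target, read by calcium flux; on this read-out higher numbers stand for larger maximal responses and lower numbers for smaller maximal responses. For the measured compounds named here, compound 2 `Cc1ccoc1-c1ccccc1OCC1=NCCN1` gives 99% in this assay, and the only measured step, a number 7 percentage points lower from compound 1 to compound 2 (within the scatter), leaves the two numbers within the scatter of each other, so compound 1 stands level with compound 2 rather than apart from it. Compound 3 `Cc1cc(-c2ccccc2OCC2=NCCN2)sn1` carries the change (3-methyl-1,2-thiazol-5-yl in place of furan-2-yl on an aromatic carbon). Going by the values given here, no measured step covers a ring exchange of this kind; the methyl step gives no guide to size or direction. Pending measurement, compound 3 is expected to give 95%, within 55% to 115%. That estimate means a number 11 percentage points lower from compound 1 to compound 3 (beyond the scatter), a step expected to stay within the scatter.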

Compound 3, largest response reached (reported as maximum), in percent of the reference or control that the assay uses: 75%
For compound 3 the middle estimate is 20 percentage points above the measured one; the measured number falls inside the stated range.
By their numbers in this assay, from the lowest: compound 3; then compounds 2 and 1 (each within the scatter of the next).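

On an aromatic carbon ortho to a group of 7 heavy atoms, the group itself proves to matter in this assay: 3-methyl-1,2-thiazol-5-yl gives a number 31 percentage points lower from compound 1 to compound 3 (beyond the scatter) in place of furan-2-yl and a number 24 percentage points lower from compound 2 to compound 3 (beyond the scatter) in place of 3-methylfuran-2-yl. The methyl on the furan made no step beyond the scatter, so the lower number goes with the ring exchange, not with the methyl alone. Nothing available explains this loss of maximal response. Open, on these data alone, is whether 1,2-thiazol-5-yl without the methyl falls as far, and how a phenyl or pyridyl group at this place compares.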